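This account rests on a few compounds, and the source may have more. Where it says the series, first, only, none or still open, it means among the compounds named here.

Working values:
- compound 1 `C/C(=C\COc1c(Cl)cccc1Cl)CC/C=C(\C)C1=CC(=O)C(C)(C)O1`: 26.2 ug/mL
- compound 2 `COc1cccc(OC/C=C(\C)CC/C=C(\C)C2=CC(=O)C(C)(C)O2)c1`: 45.8 ug/mL
- compound 3 `COc1ccc(OC/C=C(\C)CC/C=C(\C)C2=CC(=O)C(C)(C)O2)cc1`: not yet measured

Among the measured compounds shown here, in a functional assay on Raji cells (Homo sapiens) for inhibition (on this read-out lower numbers stand for stronger inhibition and higher numbers for weaker inhibition), compound 2 gives 45.8 ug/mL, within the scatter of compound 1, the only other measured compound. Compound 3 differs from it by 4-methoxyphenyl in place of 3-methoxyphenyl on an oxygen on a saturated carbon. For the measured compounds named here, the one measured change at this place, a 1.7-fold higher number from compound 1 to compound 2 (0.24 log units; within the scatter), is the only guide, so no shift beyond the scatter is expected in this assay. The expected step is a 1.1-fold lower number from compound 2 to compound 3 (0.06 log units; within the scatter). For compound 3 the estimated value is 40 ug/mL, with an expected range of 18 ug/mL to 85 ug/mL.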

Compound 3, half-maximal inhibitory concentration: 43 ug/mL
Estimate against measurement, compound 3: 1.1-fold (0.03 log units) below; the measured number falls inside the stated range.
By their numbers in this assay, from the lowest: compounds 1, 3 and 2 (each within the scatter of the next).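

In this assay, 4-methoxyphenyl in place of 3-methoxyphenyl gives a 1.1-fold lower number from compound 2 to compound 3 (0.03 log units; within the scatter), so this read-out does not separate these two methoxyphenyl groups. With 4-methoxyphenyl in place of 2,6-dichlorophenyl, the result is a 1.6-fold higher number from compound 1 to compound 3 (0.22 log units; within the scatter), which leaves all three aryl groups shown on this oxygen within the scatter of one another. No available evidence bears on why these groups read alike.

As far as these compounds go, it remains open whether any group at this place moves the number beyond the scatter. Unsubstituted phenyl, pyridyl or a phenyl carrying a carboxylic acid would test this.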